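This account rests on a few compounds, and the source may have more. Where it says the series, first, only, none or still open, it means among the compounds named here.

Compound 1 `CN(C)/C(=N/CCCCn1nc(-c2ccccc2)ccc1=O)NC#N` is examined in a functional assay on the whole organism (stomach) with Rattus norvegicus as the target (a lower number here means that less compound is needed, a higher number that more compound is needed for the effect), where compound 1 gives 30.3 mg/kg. Within the data shown here, that is the only number among the three measured compounds, as the others sit at the limit of > 100 mg/kg in this assay, at which 2 of the 3 values shown sit. For compound 2 `CC/N=C(/NC#N)NCCCCn1nc(-c2ccccc2)c(C)cc1=O` this assay reports only a limit, > 100 mg/kg. For compound 3 `O=c1ccc(-c2ccccc2)nn1CCCCNC(=S)Nc1cccc2ccccc12` this assay likewise reports only a limit, > 100 mg/kg. Compound 4 `C/N=C(/NC#N)N(C)CCCCn1nc(-c2ccccc2)ccc1=O` has not yet been measured; it differs from compound 1 by a group of 8 heavy atoms (4 carbon, 4 nitrogen; no ring) in place of a group of 8 heavy atoms (4 carbon, 4 nitrogen; no ring), on a saturated chain carbon, four bonds along the chain from an aromatic nitrogen, the two sharing the same atoms joined differently. Among the measured compounds shown here, no measured step of this kind is available. The step from compound 1 to compound 4 is expected to be small, a 1.0-fold lower number from compound 1 to compound 4 (0.00 log units; within the scatter), not clearly beyond the scatter. Compound 4 is therefore estimated at 30 mg/kg, between 12 mg/kg and 80 mg/kg.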

Compound 4, dose for half-maximal effect: > 100 mg/kg
Compound 4: only a limit was reported; the forecaster's own chance of this, stated with the estimate: 25%; at least 3.3-fold (0.52 log units) between middle value and limit.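

Joining the same atoms differently on the saturated chain carbon, four bonds along the chain from an aromatic nitrogen, gives an at least 3.3-fold higher number from compound 1 to compound 4 (0.51 log units; beyond the scatter) in this assay. This is the first step shown at this place, and it shows that the result depends on how the group is joined, even though the counts of atoms, donors and acceptors stay the same. Compound 4 gives only a limit, so the step is bounded on one side only: the limit of > 100 mg/kg in this assay, at which 3 of the 4 values shown sit.

The compounds shown leave open how a primary amine or a urea at this place would read in this assay. They also leave open whether a longer chain would change the result.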